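Lengthening the Ester Chain on a Urea Acyltransferase Inhibitor

This account rests on a few compounds, and the source may have more. Where it says the series, first, only, none or still open, it means among the compounds named here.

Of the compounds shown here, two sharing one core have been measured so far. Compound 1 `CCCCCC(C)OC(=O)NC(=O)Nc1c(C(C)C)cccc1C(C)C` carries a shorter saturated chain on the ester oxygen; in an assay on microsomes from intestine for inhibition of acyl-CoA:cholesterol acyltransferase (Oryctolagus cuniculus) (on this read-out lower numbers stand for stronger inhibition and higher numbers for weaker inhibition), compound 1 gives 1060 nM. Compound 2 `CCCCCCCCCCCCC(C)OC(=O)NC(=O)Nc1c(C(C)C)cccc1C(C)C` carries a much longer chain at the same position, and in this assay compound 2 gives 46 nM. For the measured compounds named here, the step between them, a 23-fold lower number from compound 1 to compound 2 (1.36 log units; beyond the scatter), is the only structural change whose effect is known here, and it shows a large improvement on lengthening the chain. Compound 2 therefore stands at the lower of the two numbers, with compound 1 well behind it.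

Compound 3 `CCCCCCCCCCCCCCC(C)OC(=O)NC(=O)Nc1c(C(C)C)cccc1C(C)C` extends the same chain a little further: ethyl in place of hydrogen on a saturated chain carbon, ten or more bonds along the chain from an oxygen next to a carbonyl group. This is a smaller version of the change that separated compound 1 from compound 2, so a further drop in the number is expected, but the gain from two added carbons should be modest, and a plateau cannot be excluded. The estimated step is a 1.5-fold lower number from compound 2 to compound 3 (0.19 log units; within the scatter). For compound 3 in this assay the estimate is 30 nM, in the range from 10 nM to 90 nM.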

Compound 3, half-maximal inhibitory concentration: 6800 nM
The estimate for compound 3 lay 230-fold (2.36 log units) below the measured number; the whole stated range lies below it.
By their numbers in this assay, from the lowest: compound 2; then compound 1; then compound 3.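

In this assay, lengthening the saturated chain on the ester oxygen does not keep paying off: ethyl in place of hydrogen on a saturated chain carbon gives a 150-fold higher number from compound 2 to compound 3 (2.17 log units; beyond the scatter) and so more than cancels the earlier gain. The longest chain even ends up behind the shortest, with a 6.4-fold higher number from compound 1 to compound 3 (0.81 log units; beyond the scatter), so across these three compounds the number first falls with chain length and then rises steeply, leaving compound 2 with the lowest number of the three. This small addition far out along the chain therefore matters a great deal, yet nothing available here accounts for the reversal.

As far as these compounds go, it remains open whether a chain of intermediate length between those of compound 2 and compound 3 would keep the low number of compound 2 or already share the high number of compound 3. Also open, from the compounds shown here alone, are whether a still longer chain would push the number higher, and whether an amine or a carboxylic acid in place of the ethyl would behave differently.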